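Chloro for Fluoro: What to Expect for Clearance

The compounds below may be only part of what the source reports. "The series", "measured", "known", "first", "only" and "open" are said of these compounds alone.

Four compounds share a core, and three of them have been measured in an ADME assay on microsomes from liver (Rattus norvegicus, strain Wistar) for metabolic stability, tested at 2.5 uM; on this read-out lower numbers stand for slow clearance and higher numbers for fast clearance. Compound 1 `Fc1ccc(-c2ccc(Cn3nnc4ccccc43)cc2)c(F)c1` gives 6.4 mL/min/g. Compound 2 `Fc1cc(Cl)ccc1-c1ccc(Cn2nnc3ccccc32)cc1` gives 1.3 mL/min/g, and compound 3 `Fc1ccc(Cn2nnc3c(Br)cccc32)cc1` gives 1 mL/min/g; the numbers of compound 2 and compound 3 lie within the usual scatter of each other. Compound 1 and compound 2 differ only by chloro in place of fluoro on an aromatic carbon, a change that made a 4.9-fold lower number from compound 1 to compound 2 (0.69 log units; beyond the scatter).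

Compound 4 `Clc1ccc(Cn2nnc3c(Br)cccc32)cc1` has not yet been measured. It differs from compound 3 by chloro in place of fluoro on an aromatic carbon. The difference between the cores of compound 3 and compound 1 is not broken down here. Among the measured compounds shown here, the change from compound 3 to compound 4 is the same kind of change as the one from compound 1 to compound 2, though not the same: in compound 1 the carbon that loses the fluoro is also meta to a fluoro group, whereas in compound 3 it is not.

In this assay compound 4 is expected to come in at 0.5 mL/min/g, somewhere between 0.2 mL/min/g and 1.2 mL/min/g. The expected step of a 2.0-fold lower number from compound 3 to compound 4 (0.30 log units; within the scatter) is smaller than the measured one, because the earlier step of a 4.9-fold lower number from compound 1 to compound 2 (0.69 log units; beyond the scatter) began from a higher number, while compound 3 already sits at 1 mL/min/g.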

Compound 4, intrinsic clearance in a liver preparation (reported as CLH), per the amount of preparation that the assay uses: 2.2 mL/min/g
Estimate against measurement, compound 4: 4.4-fold (0.64 log units) below, outside the stated range (above it).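

On the core of compound 3, chloro in place of fluoro gave a 2.2-fold higher number from compound 3 to compound 4 (0.34 log units; beyond the scatter) in this assay, so the number went up here, whereas it went down on the core of compound 1. The same swap therefore does not act as one fixed shift across these cores, not even in its direction: the same change on two cores in this assay, a 4.9-fold lower number (0.69 log units; beyond the scatter) from compound 1 to compound 2 and a 2.2-fold higher number (0.34 log units; beyond the scatter) from compound 3 to compound 4, 11-fold (1.03 log units) apart, beyond the scatter of two such steps

Within these four compounds, then, a step measured on one core is a poor guide to the step on the other, but this does not show which difference between the cores is responsible, and two pairs of compounds cannot set a rule for the whole series. Going by these compounds, it remains open which part of the cores decides the direction of the step, and which way it would go on a third core. Also open, on these data alone, is how a different group, such as a methoxy group, a nitrile or an amine, would compare with fluoro and chloro at this same place on either core.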